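The source may hold more compounds than are shown below. What is called first, only, known or untested is meant among the compounds shown, and "the series" means these compounds.

Working notes on the series. Compound 1 `CN(C)CCNc1nc(-c2ccc(NC(=O)Nc3ccccc3Cl)cc2)nc2c(Cl)c(Cl)sc12` gives 1170 nM in a functional assay on MKN-45 cells (Homo sapiens) for cytotoxicity, read by MTT assay, with a stated time of 72 h; a higher number here means a weaker inhibitor, a lower number a stronger inhibitor. Going by the values given here, compound 2 `CCN(CC)CCCNc1nc(-c2ccc(NC(=O)Nc3ccccc3Cl)cc2)nc2c(Cl)c(Cl)sc12` gives 1450 nM in this assay, and the only single-point step measured so far, a 1.2-fold higher number from compound 1 to compound 2 (0.09 log units; within the scatter), concerns the amino group on the saturated chain. Compound 3 `CCN(CC)CCNc1nc(-c2ccc(NC(=O)Nc3ccc(F)cc3)cc2)nc2c(Cl)c(Cl)sc12` gives 1370 nM in this assay; on the three numbers shown it lies within the scatter of both compound 1 and compound 2. Among the compounds with values here, compound 4 `CCN(CC)CCNc1nc(-c2ccc(NC(=O)Nc3ccccc3Cl)cc2)nc2c(Cl)c(Cl)sc12` carries 2-chlorophenyl in place of 4-fluorophenyl on an amide-type nitrogen, a change on the amide-type nitrogen that no measured step addresses. Compound 1 and compound 2, which also carry the 2-chlorophenyl group, show numbers in the same band as compound 3. The step expected in this assay is a 1.1-fold lower number from compound 3 to compound 4 (0.02 log units; within the scatter), none beyond the scatter. For compound 4 the estimate is 1300 nM, within 650 nM to 2600 nM.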

Compound 4, half-maximal inhibitory concentration: 1130 nM
Beside the measured number, compound 4's estimate is 1.2-fold (0.06 log units) above it, and the stated range covers the measured number.
By their numbers in this assay, from the lowest: compounds 4, 1, 3 and 2 (each within the scatter of the next).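

In this assay, 2-chlorophenyl in place of 4-fluorophenyl on the amide-type nitrogen gives a 1.2-fold lower number from compound 3 to compound 4 (0.08 log units; within the scatter) and so shows no readable effect of this change at this position. With 2-chlorophenyl held fixed, diethylamino in place of dimethylamino gives a 1.0-fold lower number from compound 1 to compound 4 (0.02 log units; within the scatter) and diethylamino in place of (diethylamino)methyl gives a 1.3-fold lower number from compound 2 to compound 4 (0.11 log units; within the scatter) so neither change on the chain has a readable effect either. No measured evidence bears on these results. Going by these compounds, whether a carboxylic acid in place of diethylamino, or a longer chain on the amide-type nitrogen, would move the number beyond the scatter stays open.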